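Replacing Dichlorophenyl with Methoxynaphthyl on the Shared Core

The source may report more compounds than this note shows. Statements on the series, on what has been measured and on what is new or still open speak of the compounds shown alone.

Of the compounds shown here, three built on one shared core have been tested in a functional assay on Ehrlich cells (Mus musculus) for antiproliferative activity, read by trypan blue exclusion, with a stated time of 2 h, tested at 100 ug/mL; a lower number here means a weaker effect, a higher number a stronger effect of the compound at the concentration tested. Compound 1 `COc1ccc(C2C(C#N)=C(N)N(c3ccc(S(N)(=O)=O)cc3)C3=C2C(=O)CCC3)cc1` gives 100%, compound 2 `COc1cc(CC2C(C#N)=C(N)N(c3ccc(S(N)(=O)=O)cc3)C3=C2C(=O)CCC3)ccc1O` gives 100%, and compound 3 `N#CC1=C(N)N(c2ccc(S(N)(=O)=O)cc2)C2=C(C(=O)CCC2)C1c1ccc(Cl)cc1Cl` gives 95%. On the numbers alone compound 3 sits at the bottom of the three, yet a number 5 percentage points lower from compound 1 to compound 3 (within the scatter) and a number 5 percentage points lower from compound 2 to compound 3 (within the scatter) both fall within the usual scatter, so the three cannot be told apart.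

Compound 4 `COc1ccc(C2C(C#N)=C(N)N(c3ccc(S(N)(=O)=O)cc3)C3=C2C(=O)CCC3)c2ccccc12` is not yet measured. It differs from compound 3 in one place: 4-methoxynaphthalen-1-yl in place of 2,4-dichlorophenyl on a saturated ring carbon.

For the measured compounds named here, two measured steps bear on this change, since each also exchanges the group on that saturated ring carbon: a number 5 percentage points lower from compound 1 to compound 3 (within the scatter) and a number 5 percentage points lower from compound 2 to compound 3 (within the scatter). Neither moved the read-out beyond the scatter, and every group tried there has left the activity at or near the top of the scale.

Compound 4 is therefore expected to show no step beyond the scatter, no change at the digits printed from compound 3 to compound 4 (within the scatter). The estimate for compound 4 in this assay is 95%, with a range from 80% to 100%; this rests only on compounds 1, 2 and 3, and a naphthyl group has not been tested here before.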

Compound 4, a percentage reported as activity, at one concentration (the size of the read-out at that concentration, not a potency): 90%
The estimate for compound 4 lay 5 percentage points above the measured number; the measured number falls inside the stated range.
By their numbers in this assay, from the lowest: compounds 4, 3, 1 and 2 (each within the scatter of the next).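

On the saturated ring carbon of the shared core, 4-methoxynaphthalen-1-yl, with two six-membered aromatic rings, can take the place of 2,4-dichlorophenyl, with one, and this assay shows a number 5 percentage points lower from compound 3 to compound 4 (within the scatter). Set against the two remaining groups, the same new group gives a number 10 percentage points lower from compound 2 to compound 4 (within the scatter) and a number 10 percentage points lower from compound 1 to compound 4 (within the scatter), so the position has now held four different groups without any step beyond the scatter, even with this second aromatic ring added. Nothing available explains why these four groups cannot be told apart in this read-out.

All four compounds sit at or near the top of the scale at a single concentration, so the compounds shown cannot reveal whether differences among these groups would emerge at lower concentrations. For the compounds shown here, it also remains open whether a group of a different kind on that saturated ring carbon, such as an aliphatic amine, a carboxylic acid or a simple methyl, would keep the read-out near the top of the scale or bring the first step beyond the scatter.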